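The source may report more compounds than this note shows. Statements on the series, on what has been measured and on what is new or still open speak of the compounds shown alone.

Measured so far:
- Compound 1 `O=C(Nc1ccc(O)c(C(=O)O)c1)c1ccc(N2C(=O)CCS2(=O)=O)cc1`: 89%
- Compound 2 `O=C(Nc1ccc(O)c(C(=O)O)c1)c1ccc(NC(=O)C2CC2)cc1`: 50%

In an assay on isolated protein for inhibition of NAD-dependent protein deacylase sirtuin-6 (Homo sapiens), read by fluorescence, tested at 200 uM (on this read-out lower numbers stand for less inhibition and higher numbers for more inhibition at the one concentration tested (going by the name of the read-out)), compound 2 gives 50%, the lower of the two numbers, and compound 1 gives 89%. Going by the values given here, the one measured step, a number 39 percentage points lower from compound 1 to compound 2 (beyond the scatter), concerns a different part of the molecule and therefore does not speak directly to the change now considered.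

Compound 3 `O=C(Nc1ccc(O)c(C(=O)O)c1)c1ccc(NC(=O)c2ccco2)cc1` differs from compound 2 in one place: furan-2-yl in place of cyclopropyl on a carbonyl carbon. Both groups sit on the same carbonyl carbon of the amide, so the shared core and the rest of the molecule stay unchanged. Among the compounds with values here, with no measured step that exchanges the group on this carbonyl, there is nothing to suggest a large shift in either direction, and a step within the scatter seems most likely.

Compound 3 is therefore expected to give about 55% in this assay, in a range from 30% to 80%, which means an expected step of a number 5 percentage points higher from compound 2 to compound 3 (within the scatter).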

Compound 3, a percentage reported as inhibition, at one concentration (the size of the read-out at that concentration, not a potency): 100%
Compound 3: middle estimate off by 45 percentage points, on the low side, and the stated range ends below it.
By their numbers in this assay, from the lowest: compound 2; then compound 1; then compound 3.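

The group on this carbonyl carbon has a strong effect in this assay: furan-2-yl in place of cyclopropyl gives a number 50 percentage points higher from compound 2 to compound 3 (beyond the scatter), showing that an exchange at this one place, with the rest of the molecule unchanged, can shift inhibition by a large amount. Against the different group on the aromatic carbon in compound 1, the whole ((furan-2-yl)carbonyl)amino group gives a number 11 percentage points higher from compound 1 to compound 3 (beyond the scatter), so an open amide can match or pass that five-membered ring at this single concentration. Nothing measured here explains either step.

On these data alone, it remains open which feature of furan-2-yl matters: its ring oxygen, its ring size or its aromatic ring. Thiophen-2-yl, phenyl or cyclopentyl on the same carbonyl carbon would help to tell these apart.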